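Chlorine position on the pendant phenyl of the shared core

This account rests on a few compounds, and the source may have more. Where it says the series, first, only, none or still open, it means among the compounds named here.

Compound 1 `CC(=O)N1N=C(c2ccc(O)cc2)CC1c1ccccc1Cl` and compound 2 `CC(=O)N1N=C(c2ccc(O)cc2)CC1c1cccc(Cl)c1` share one core and differ only in the placement of chlorine on the phenyl at the saturated ring carbon. In an assay on isolated protein for inhibition of Monoamine oxidase (Homo sapiens) (on this read-out lower numbers stand for stronger inhibition and higher numbers for weaker inhibition), compound 1 gives 50000 nM; compound 2 gives 12000 nM in this assay. Among the measured compounds shown here, the only measured step, a 4.2-fold lower number from compound 1 to compound 2 (0.62 log units; beyond the scatter), leaves compound 2 with the lowest of the two numbers. Compound 3 `CC(=O)N1N=C(c2ccc(O)cc2)CC1c1ccc(Cl)cc1` is the next point: 4-chlorophenyl in place of 3-chlorophenyl on a saturated ring carbon. For the measured compounds named here, only that one step bears on the change, and it was modest; no measured pair covers a move of chlorine from the 3-position to the 4-position, so direction is open. For compound 3 the expected step is a 1.5-fold lower number from compound 2 to compound 3 (0.18 log units; within the scatter) in this assay, a small shift toward lower numbers given a 4.2-fold lower number from compound 1 to compound 2 (0.62 log units; beyond the scatter), with wide uncertainty. Compound 3 is estimated at 8000 nM, within 2500 nM to 25000 nM.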

Compound 3, half-maximal inhibitory concentration: 40000 nM
The estimate for compound 3 lay 5.0-fold (0.70 log units) below the measured number; the measured number lies above the stated range.
By their numbers in this assay, from the lowest: compound 2; then compounds 3 and 1 (each within the scatter of the next).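

The move to 4-chlorophenyl gives a 3.3-fold higher number from compound 2 to compound 3 (0.52 log units; beyond the scatter), so the shift toward lower numbers seen on going to 3-chlorophenyl does not continue, and in this assay compound 2 holds the lowest number of the three placements. The 2-chlorophenyl and 4-chlorophenyl placements are not separated, with a 1.3-fold lower number from compound 1 to compound 3 (0.10 log units; within the scatter), which leaves 3-chlorophenyl as the only placement that stands apart. Nothing at hand explains this difference between placements.

Going by these compounds, whether 3-fluorophenyl, 3-methoxyphenyl or 3-aminophenyl would follow 3-chlorophenyl remains open, so the result cannot yet be tied to chlorine itself. Also open, on these data alone, is whether the same order of placements holds when a propanoyl group stands in place of the acetyl group on the shared core.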